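Swapping bromo for chloro on a cytotoxicity series

The compounds below may be only part of what the source reports. "The series", "measured", "known", "first", "only" and "open" are said of these compounds alone.

Measured compounds:
- compound 1, `CC(=O)N1N=C(c2ccc(-n3c(C)ccc3C)cc2)OC1c1ccccc1Cl`, 206000 nM
- compound 2, `O=C(NNC(=O)c1ccc(F)c(C(F)(F)F)c1)c1ccc(-n2cccc2)cc1`, 200000 nM
- compound 3, `Brc1ccc(-c2nnc(-c3ccc(-n4cccc4)cc3)o2)cc1`, 264000 nM

The three compounds were tested in an ADME assay on A549 cells (Homo sapiens) for cytotoxicity, read by MTT assay, with a stated time of 72 h; on this read-out higher numbers stand for weaker inhibition and lower numbers for stronger inhibition. On this read-out compound 3 gives 264000 nM, the highest of the three numbers, but its gap to compound 1 and its gap to compound 2 both fall within the usual scatter of repeated measurements, so none of the three can be called weaker or stronger than the others. All three sit at very high concentrations, meaning each is barely toxic to these cells.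

Compound 4, `Clc1ccc(-c2nnc(-c3ccc(-n4cccc4)cc3)o2)cc1`, has not yet been measured. It differs from compound 3 in one place: chloro in place of bromo on an aromatic carbon. Both halogens are single heavy atoms sitting on the same aromatic carbon of the same six-membered carbon ring, and neither change alters the count of hydrogen-bond donors or acceptors.

For the measured compounds named here, no pair of measured compounds here shows what such a change does in this assay. With compound 3 at 264000 nM and so small a structural change, the expected step from compound 3 to compound 4 is a 1.1-fold lower number from compound 3 to compound 4 (0.02 log units; within the scatter), that is, no movement beyond the scatter in either direction. Compound 4 is therefore estimated at 250000 nM, with a plausible range from 120000 nM to 520000 nM.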

Compound 4, half-maximal inhibitory concentration: 256000 nM
The estimate for compound 4 lay 1.0-fold (0.01 log units) below the measured number, and the stated range covers the measured number.
By their numbers in this assay, from the lowest: compounds 2, 1, 4 and 3 (each within the scatter of the next).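

In this assay, for the compounds shown here, replacing the 4-bromophenyl group with the 4-chlorophenyl group gives a 1.0-fold lower number from compound 3 to compound 4 (0.01 log units; within the scatter), and this is the first pair in the set that differs in only one place. It shows that, at this position on an aromatic carbon para to a large group, chloro and bromo cannot be told apart on this read-out. Both compounds remain at the very high concentrations seen across the set, so exchanging one halogen for the other leaves these compounds barely toxic to the cells, and no measurement shown here offers an explanation for this result.

The compounds shown leave open whether a different kind of group at this place, such as an amine or a carboxylic acid, would give a number clearly apart from these. They also leave open whether the same halogen swap would stay just as silent in a compound with a much lower number on this read-out, one that is clearly toxic to these cells.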